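From Furan to Pyridine on the Amine Arm

This account rests on a few compounds, and the source may have more. Where it says the series, first, only, none or still open, it means among the compounds named here.

Compound 2 `c1ccc(C(c2ccccc2)[C@@H]2CC[C@H](NCc3ccco3)CO2)cc1` gives 110 nM in an assay on striatum for inhibition of sodium-dependent dopamine transporter (Rattus norvegicus) (on this read-out higher numbers stand for weaker inhibition and lower numbers for stronger inhibition), the highest of the two numbers recorded so far; its nearest neighbour is compound 1 `c1ccc(C(c2ccccc2)[C@@H]2CC[C@H](NCc3ccc[nH]3)CO2)cc1`, which gives 43.2 nM in this assay. Within the data shown here, the step of a 2.5-fold higher number from compound 1 to compound 2 (0.41 log units; beyond the scatter) is the only measured step, and it alters the same arm that is altered now. Compound 3 `c1ccc(C(c2ccccc2)[C@@H]2CC[C@H](NCc3ccccn3)CO2)cc1` differs from compound 2 by pyridin-2-yl in place of furan-2-yl on a saturated chain carbon bound to an amine nitrogen. Among the measured compounds shown here, no measured pair exchanges a five-membered aromatic ring for a six-membered one, so the single recorded step serves only as a rough guide to the size such exchanges take on this arm. Compound 3 is therefore expected to show a step of about a 1.2-fold lower number from compound 2 to compound 3 (0.09 log units; within the scatter) in this assay, which may well fall within the scatter in either direction. The estimate for compound 3 is 90 nM, with a range from 30 nM to 300 nM.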

Compound 3, inhibition constant: 209 nM
Estimate against measurement, compound 3: 2.3-fold (0.37 log units) below; low and high end bracket the measured number.
By their numbers in this assay, from the lowest: compound 1; then compounds 2 and 3 (each within the scatter of the next).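

In this assay, pyridin-2-yl in place of furan-2-yl on a saturated chain carbon bound to an amine nitrogen gives a 1.9-fold higher number from compound 2 to compound 3 (0.28 log units; within the scatter), so this exchange of a five-membered aromatic ring for a six-membered one cannot be told from the scatter. Pyridin-2-yl in place of 1H-pyrrol-2-yl gives a 4.8-fold higher number from compound 1 to compound 3 (0.68 log units; beyond the scatter), and with a 2.5-fold higher number from compound 1 to compound 2 (0.41 log units; beyond the scatter) this sets compound 1 apart from both other compounds, as the only one whose steps to the others are both beyond the scatter. Nothing measured here accounts for these steps.

The compounds shown leave open how the number responds when the ring nitrogen is moved, as in pyridin-3-yl or pyridin-4-yl, or is absent, as in phenyl. They also leave open what a longer chain between the amine nitrogen and the ring would do.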